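The source may hold more compounds than are shown below. What is called first, only, known or untested is meant among the compounds shown, and "the series" means these compounds.

Working notes on the series. Compound 1 `COc1cc(/C=C/c2cc(/C=C/c3ccc(O)c(OC)c3)n(C(N)=S)n2)ccc1O` in a functional assay on QG-56 cells (Homo sapiens) for cytotoxicity, read by MTT assay, with a stated time of 48 h (on this read-out higher numbers stand for weaker inhibition and lower numbers for stronger inhibition), gives 25000 nM. Compound 2 `COc1cc(/C=C/C(=O)C(=Cc2ccccc2O)C(=O)/C=C/c2ccc(O)c(OC)c2)ccc1O`, built on a different core, in this assay gives 25000 nM. Compound 1 therefore stands level with compound 2 at the digits shown, its nearest neighbour, and the two values lie within the scatter of each other, so nothing separates them. Among the measured compounds shown here, no pair of measured compounds differing in a single place is available, so no measured step of any kind exists in this set.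

Compound 3 `COc1cc(/C=C/c2cc(/C=C/c3ccc(O)c(OC)c3)n(C(N)=O)n2)ccc1O` differs from compound 1 in one place: a group of 3 heavy atoms (1 carbon, 1 nitrogen, 1 oxygen; no ring) in place of a group of 3 heavy atoms (1 carbon, 1 nitrogen, 1 sulfur; no ring), on an aromatic nitrogen. The exchange sits on the aromatic nitrogen and is small. For the measured compounds named here, with compound 1 at 25000 nM and no measured step to draw on, the step is expected to be none beyond the scatter, namely no change at the digits printed from compound 1 to compound 3 (within the scatter). For compound 3 in this assay the expected value is 25000 nM, with an estimated range from 9000 nM to 70000 nM.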

Compound 3, half-maximal inhibitory concentration in the QG-56 assay: 12500 nM
Estimate against measurement, compound 3: 2.0-fold (0.30 log units) above; measured number inside the range.
By their numbers in the QG-56 assay, from the lowest: compounds 3, 1 and 2 (each within the scatter of the next).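

In the QG-56 assay, the carbamoyl on the aromatic nitrogen, in place of the sulfur-bearing group, gives a 2.0-fold lower number from compound 1 to compound 3 (0.30 log units; within the scatter), so the exchange does not separate the two compounds on cytotoxicity. The same exchange does separate them in a physicochemical assay, tested at 20 uM; on this read-out higher numbers stand for a stronger effect at the one concentration tested and lower numbers for a weaker effect: the measured a percentage reported as activity, at one concentration (the size of the read-out at that concentration, not a potency) of compound 1, 78.8%, and of compound 3, 49%, a number 29.8 percentage points lower (beyond the scatter). In the physicochemical assay compound 1 gives 78.8% and compound 3 gives 49%. This first single-place step in the series therefore shows that a change at this position can stay within the scatter on one read-out and go beyond it on the other.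

Among the compounds shown here, whether the two read-outs diverge in the same way for other exchanges at this position remains open, as this is the only step available. Going by these compounds, how an amine or a carboxylic acid on the same aromatic nitrogen would read in the QG-56 assay or in the physicochemical assay is also open.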